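Swapping chloro for fluoro in a cytotoxicity series

A few compounds are considered here, and "the series" means these few. Any claim that something is new, unique, unknown or untested is made for them only; others in the source may bear on it.

Compound 2 `Cc1cc(S(N)(=O)=O)ccc1NC(=O)COc1ccc(Cl)cc1Oc1ccc2cc(Br)ccc2c1` was tested in an ADME assay on C8166 cells (Homo sapiens) for cytotoxicity, read by MTT assay (a higher number here means that more compound is tolerated, a lower number that less compound is tolerated), and gives 31300 nM. Compound 1 `Cc1cc(S(N)(=O)=O)ccc1NC(=O)COc1ccc(F)cc1Oc1cccc2ccccc12` gives 33100 nM, and compound 3 `Cc1cc(S(N)(=O)=O)ccc1NC(=O)COc1ccc(Cl)cc1Oc1ccc2ccccc2c1Br` gives 48100 nM; both lie within the scatter of compound 2. Compound 4 `Cc1cc(S(N)(=O)=O)ccc1NC(=O)COc1ccc(F)cc1Oc1ccc2cc(Br)ccc2c1` differs from compound 2 by fluoro in place of chloro on an aromatic carbon. Going by the values given here, no measured step isolates this change: the only single-point step, a 1.5-fold higher number from compound 2 to compound 3 (0.19 log units; within the scatter), concerns the bromine position on the naphthalene and stayed within the scatter, while compound 1 and compound 2 differ in two places at once and their two values are close. On this basis compound 4 is expected to show a 1.1-fold higher number from compound 2 to compound 4 (0.02 log units; within the scatter) in this assay, nothing beyond the scatter. The estimate for compound 4 is 33000 nM, ranging from 16000 nM to 66000 nM.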

Compound 4, half-maximal cytotoxic concentration: > 357000 nM
Compound 4 was reported as a limit; the forecaster's own chance of this, stated with the estimate: 5%; middle value at least 10-fold (1.03 log units) from the limit.
By their numbers in this assay, from the lowest: compounds 2, 1 and 3 (each within the scatter of the next). At a limit, above all of these: compound 4.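

In this assay, going by these compounds alone, fluoro in place of chloro on this aromatic carbon gives an at least 11-fold higher number from compound 2 to compound 4 (1.05 log units; beyond the scatter), a large step, whereas moving the bromine among the earlier compounds gave only a 1.5-fold higher number from compound 2 to compound 3 (0.19 log units; within the scatter). Fluoro alone does not settle the outcome, since with fluoro kept, 6-bromonaphthalen-2-yl in place of naphthalen-1-yl gives an at least 10-fold higher number from compound 1 to compound 4 (1.03 log units; beyond the scatter). The figure for compound 4 is a limit, not a number: the limit of > 357000 nM in this assay, at which 1 of the 4 values shown sits.

As far as these compounds go, whether hydrogen, methyl or methoxy at this position would track fluoro or chloro remains open. So does whether fluoro gives the same step alongside 1-bromonaphthalen-2-yl.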